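Dropping the methylsulfonyl group from a fused pyridinone-oxadiazole

A few compounds are considered here, and "the series" means these few. Any claim that something is new, unique, unknown or untested is made for them only; others in the source may bear on it.

Compounds measured so far:
compound 1, `CS(=O)(=O)c1ccc(-c2cnc3[nH]cc(-c4nnc(-c5ccc(F)cc5)o4)c(=O)c3c2)cc1`, 18.7%
compound 2, `CS(=O)(=O)c1ccc(-c2cnc3[nH]cc(-c4nnc(-c5ccc(Cl)cc5)o4)c(=O)c3c2)cc1`, 17%

Of the compounds shown here, two have been tested in a functional assay on HCT-116 cells (Homo sapiens) for inhibition, read by MTT assay, with a stated time of 24 h, tested at 10 uM; on this read-out lower numbers stand for less inhibition of growth and higher numbers for more inhibition of growth at the one concentration tested. Compound 1 `CS(=O)(=O)c1ccc(-c2cnc3[nH]cc(-c4nnc(-c5ccc(F)cc5)o4)c(=O)c3c2)cc1` gives 18.7%, and compound 2 `CS(=O)(=O)c1ccc(-c2cnc3[nH]cc(-c4nnc(-c5ccc(Cl)cc5)o4)c(=O)c3c2)cc1` gives 17%. Among the measured compounds shown here, the only step between them, a number 1.7 percentage points lower from compound 1 to compound 2 (within the scatter), lies within the scatter, so the two numbers cannot be told apart, and compound 2 stands level with compound 1 rather than above or below it.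

Compound 3 `O=c1c(-c2nnc(-c3ccc(Cl)cc3)o2)c[nH]c2ncc(-c3ccccc3)cc12` has not been measured. It differs from compound 2 by hydrogen in place of methylsulfonyl on an aromatic carbon. For the measured compounds named here, no measured step involves this change; the single step on record swaps one halogen for another on a different ring and moved nothing beyond the scatter. There is therefore no basis for expecting a step in either direction in this assay, and the estimate simply follows the value of compound 2 with a wide range. Compound 3 is expected to give 15%, between 3% and 32%, which would mean an expected step of a number 2 percentage points lower from compound 2 to compound 3 (within the scatter).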

Compound 3, percent growth inhibition at one concentration: 21.6%
The estimate for compound 3 lay 6.6 percentage points below the measured number, within the range that was stated.
By their numbers in this assay, from the lowest: compounds 2, 1 and 3 (each within the scatter of the next).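

In this assay, replacing the methylsulfonyl group with hydrogen on the phenyl ring gives a number 4.6 percentage points higher from compound 2 to compound 3 (within the scatter). Among the compounds shown here, this is the first look at the ring that carries this group, as the only earlier step concerned a halogen on a different ring, and it shows that the change from 4-(methylsulfonyl)phenyl to phenyl can be made without a difference that can be told from the scatter: four heavy atoms and two hydrogen-bond acceptors leave the molecule, and the read-out cannot separate the two compounds. No measurement at hand bears on why this change makes so little difference.

The compounds shown leave open whether a different group on this same carbon, such as an amine or a carboxylic acid, would move the number beyond the scatter, or whether any group there matters at all in this read-out. They also leave open whether removing methylsulfonyl would give a similar result with fluoro in place of chloro on the other ring, as in the counterpart of compound 1.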